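Fluoro in place of hydrogen: a step from one precedent

The compounds below may be only part of what the source reports. "The series", "measured", "known", "first", "only" and "open" are said of these compounds alone.

Among the compounds with values here, in a functional assay on CCRF-CEM cells (Homo sapiens) for inhibition (a higher number here means a weaker inhibitor, a lower number a stronger inhibitor), compound 2 (`O=C1O/C(=C\Cn2ccc(=O)[nH]c2=O)C(OCc2ccccc2)=C1OCc1ccccc1`) gives 13000 nM, the highest of the three numbers so far. Compound 3 (`O=C1O/C(=C\Cn2cnc3c(-n4cccc4)ncnc32)C(OCc2ccccc2)=C1OCc1ccccc1`) gives 5800 nM, and compound 1 (`O=C1O/C(=C\Cn2cc(I)c(=O)[nH]c2=O)C(OCc2ccccc2)=C1OCc1ccccc1`) gives 3300 nM. Compound 4 (`O=C1O/C(=C\Cn2cc(F)c(=O)[nH]c2=O)C(OCc2ccccc2)=C1OCc1ccccc1`) differs from compound 2 by fluoro in place of hydrogen on an aromatic carbon. Within the data shown here, one measured step bears on this carbon: a 3.9-fold higher number from compound 1 to compound 2 (0.60 log units; beyond the scatter), a modest change beyond the scatter on replacing iodo with hydrogen. Read backwards, that step suggests a lower number, but iodo is the only precedent, so a smaller move is expected, possibly none beyond the scatter. The expected change is a 1.5-fold lower number from compound 2 to compound 4 (0.18 log units; within the scatter). For compound 4 the estimate is 8500 nM, with an expected range of 3800 nM to 18000 nM.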

Compound 4, half-maximal inhibitory concentration: 15100 nM
For compound 4 the middle estimate is 1.8-fold (0.25 log units) below the measured one, and the stated range covers the measured number.
By their numbers in this assay, from the lowest: compounds 1 and 3 (each within the scatter of the next); then compounds 2 and 4 (each within the scatter of the next).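

In this assay, fluoro on this carbon does not behave as iodo does: a 1.2-fold higher number from compound 2 to compound 4 (0.07 log units; within the scatter) stays within the scatter, whereas a 4.6-fold higher number from compound 1 to compound 4 (0.66 log units; beyond the scatter) lies beyond it. The earlier gain from iodo over hydrogen therefore does not extend to every halogen on this carbon. Nothing measured here accounts for the difference between fluoro and iodo. From the compounds shown here alone, whether iodo is a lone case remains open. Chloro, bromo or methyl on the same carbon would show whether any other group matches it.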